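The compounds below may be only part of what the source reports. "The series", "measured", "known", "first", "only" and "open" are said of these compounds alone.

Measured compounds in an ADME assay on HepG2 cells (Homo sapiens) for inhibition, with a stated time of 72 h; a higher number here means that more compound is needed for the effect, a lower number that less compound is needed:
Compound 1 `O=C(Nc1ccc(Cl)cc1)c1cc([N+](=O)[O-])ccc1Cl` gives only a limit, > 25000 nM.
Compound 2 `CC(Cl)C(=O)Nc1cccc(-c2nc3ccccc3s2)c1` likewise gives only a limit, > 25000 nM.
Compound 3 `O=C(Nc1cccc(-c2nc3ccccc3s2)c1)c1cc([N+](=O)[O-])cnc1Cl` also gives only a limit, > 25000 nM.

Compound 2 therefore stands at a limit, not at a number, and the two other values shown are limits as well; all three sit at the limit of > 25000 nM in this assay, at which 3 of the 3 values shown sit. Compound 4 `O=C(Nc1cccc(-c2nc3ccccc3s2)c1)c1cnc(Cl)s1` differs from compound 2 by 2-chloro-1,3-thiazol-5-yl in place of 1-chloroethyl on a carbonyl carbon. Within the data shown here, no step between two measured compounds is available, so the size of this change cannot be read from the data. With every value shown at the limit, no step beyond the scatter is expected in this assay, and compound 4 is expected to remain near that limit. Compound 4 is estimated at 30000 nM, within 8000 nM to 100000 nM. This corresponds to an expected step that the limit leaves unreadable from compound 2 to compound 4.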

Compound 4, half-maximal effective concentration: > 25000 nM
Compound 4 ended at the assay's limit; the forecaster's own chance of this, stated with the estimate: 80%; the middle value lies beyond the limit too.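

No step can be read between compound 2 and compound 4, since both values are limits and not numbers: the limit of > 25000 nM in this assay, at which 4 of the 4 values shown sit. The compounds shown leave open which structure, if any, would give a measurable number here.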